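The compounds below may be only part of what the source reports. "The series", "measured", "known", "first", "only" and "open" are said of these compounds alone.

Working notes on the series. Compound 3 `O=C(O)Cc1sc(C(c2ccc(F)cc2)c2ccc(F)cc2)nc1-c1ccco1` gives 18 nM in an in vitro assay on HEK385-7 cells for displacement of a labelled ligand from prostaglandin D2 receptor 2 (Homo sapiens) (on this read-out higher numbers stand for weaker inhibition and lower numbers for stronger inhibition), the lowest of the three numbers recorded so far. Compound 2 `CCC(c1ccccc1)c1nc(-c2ccc(Cl)cc2)c(CC(=O)O)s1` gives 190 nM in this assay, a higher number, beyond the scatter. Compound 1 `O=C(O)Cc1sc(C(c2ccccc2)c2ccccc2)nc1-c1ccccc1` gives 570 nM in this assay, the furthest away, higher and also beyond the scatter. Compound 4 `O=C(O)Cc1sc(C(c2ccc(F)cc2)c2ccc(F)cc2)nc1-c1cccc(F)c1` has not yet been measured. It differs from compound 3 in one place: 3-fluorophenyl in place of furan-2-yl on an aromatic carbon. For the measured compounds named here, no pair of measured compounds differs in that place alone, so no step is known for it. Compound 1 carries a six-membered aromatic ring of carbon only at that position, but differs from compound 3 elsewhere as well, so its value cannot be read as a step. A modest weakening of a 2.2-fold higher number from compound 3 to compound 4 (0.35 log units; beyond the scatter) is expected for compound 4, giving an estimated 40 nM with a range from 12 nM to 150 nM.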

Compound 4, half-maximal inhibitory concentration: 1.4 nM
Beside the measured number, compound 4's estimate is 29-fold (1.46 log units) above it; measured number outside the range, below it.
By their numbers in this assay, from the lowest: compound 4; then compound 3; then compound 2; then compound 1.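

For the compounds shown here, on the aromatic carbon next to the ring nitrogen, 3-fluorophenyl in place of furan-2-yl gives a 13-fold lower number from compound 3 to compound 4 (1.11 log units; beyond the scatter) in this assay and is the first step readable at this position. The position is therefore sensitive to the group it carries, and a six-membered aromatic ring of carbon only is accepted there with the rest of compound 3 unchanged. No measurement in hand accounts for the size of this step.

On these data alone, whether the fluorine or the phenyl ring carries the step stays open. Also open, as far as these compounds go, is how unsubstituted phenyl, 4-fluorophenyl or pyridyl would read at this position.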